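Bromo in Place of Fluoro: Expectation for Compound 4

A few compounds are considered here, and "the series" means these few. Any claim that something is new, unique, unknown or untested is made for them only; others in the source may bear on it.

Going by the values given here, compound 3 `COc1ccc(C(=O)Nc2ccccc2F)cc1OC1CCCC1` gives 10700 nM in an assay on isolated protein for inhibition of phosphodiesterase 4A (Sus scrofa) (on this read-out lower numbers stand for stronger inhibition and higher numbers for weaker inhibition), the highest of the three numbers measured so far. Compound 1 `COc1ccc(C(=O)Nc2ccccc2Cl)cc1OC1CCCC1` gives 190 nM and compound 2 `COc1ccc(C(=O)Nc2ccccc2C)cc1OC1CCCC1` gives 300 nM; the step of a 56-fold higher number from compound 1 to compound 3 (1.75 log units; beyond the scatter) and the step of a 36-fold higher number from compound 2 to compound 3 (1.55 log units; beyond the scatter) both lie beyond the scatter, whereas a 1.6-fold higher number from compound 1 to compound 2 (0.20 log units; within the scatter). Compound 4 `COc1ccc(C(=O)Nc2ccccc2Br)cc1OC1CCCC1` differs from compound 3 by bromo in place of fluoro on an aromatic carbon. Both measured steps onto the fluoro compound were large rises, so moving from fluoro to another halogen, bromo, is expected to bring the number down by a comparable amount. Compound 4 is therefore estimated at 250 nM, with a range of 90 nM to 1000 nM, which means an expected step of a 43-fold lower number from compound 3 to compound 4 (1.63 log units; beyond the scatter) that should lie beyond the scatter.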

Compound 4, half-maximal inhibitory concentration: 130 nM
Compound 4: the middle estimate sits 1.9-fold (0.28 log units) above what was measured; low and high end bracket the measured number.
By their numbers in this assay, from the lowest: compounds 4, 1 and 2 (each within the scatter of the next, the first and the last beyond it); then compound 3.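

With an 82-fold lower number from compound 3 to compound 4 (1.92 log units; beyond the scatter) fluoro now stands apart at this position from bromo as well as from chloro and methyl, so the weak value belongs to the fluoro compound alone among the four. Bromo in place of chloro gives a 1.5-fold lower number from compound 1 to compound 4 (0.16 log units; within the scatter) and the two cannot be told apart here, whereas bromo in place of methyl gives a 2.3-fold lower number from compound 2 to compound 4 (0.36 log units; beyond the scatter) as a modest step. Nothing available explains why fluoro differs from the other three groups. As far as these compounds go, whether a methoxy group, a trifluoromethyl group or plain hydrogen at this position would side with fluoro or with the other three stays open.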